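The source may report more compounds than this note shows. Statements on the series, on what has been measured and on what is new or still open speak of the compounds shown alone.

Compound 1 `N#Cc1cnc(NCc2cnccc2C(F)(F)F)cc1N[C@H]1C[C@H](O)C1`: in an assay on isolated protein for inhibition of protein kinase C delta type (Homo sapiens), read by TR-FRET, with a stated time of 2 h (a lower number here means a stronger inhibitor, a higher number a weaker inhibitor), compound 1 gives > 10000 nM, which is a limit of the assay and not a number. Compound 2 `CO[C@H]1CC[C@@H](Nc2cc(NCc3cnccc3C(F)(F)F)ncc2C#N)CC1`: compound 2 gives 5000 nM. Compound 3 `N#Cc1cnc(NCc2cnccc2C(F)(F)F)cc1NCC1CCOCC1`: compound 3 gives 5000 nM.

Compound 3 stands level with compound 2, since no change at the digits printed from compound 2 to compound 3 (within the scatter). The move to compound 4 `CC1(C)C[C@@H](Nc2cc(NCc3cnccc3C(F)(F)F)ncc2C#N)CC[C@H]1O` is 4-hydroxy-3,3-dimethylcyclohexyl in place of (oxan-4-yl)methyl on a nitrogen on an aromatic ring. Going by the values given here, two measured steps bear on this exchange of the ring: an at least 2.0-fold lower number from compound 1 to compound 2 (0.30 log units; that floor lies within the scatter) and an at least 2.0-fold lower number from compound 1 to compound 3 (0.30 log units; that floor lies within the scatter), both starting from the limit of > 10000 nM in this assay, at which 1 of the 3 values shown sits, and therefore floors only. The entering group carries one hydrogen-bond donor, as the ring in compound 1 does, but on a six-membered ring, as in compound 2, so a small step in this assay toward a higher number, within the scatter of compound 3, is expected, a 1.2-fold higher number from compound 3 to compound 4 (0.08 log units; within the scatter). Compound 4 is estimated at 6000 nM, within 2500 nM to 15000 nM.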

Compound 4, half-maximal inhibitory concentration: 2400 nM
Compound 4: middle estimate off by 2.5-fold (0.40 log units), on the high side; the measured number lies below the stated range.
By their numbers in this assay, from the lowest: compound 4; then compounds 2 and 3 (each within the scatter of the next). At a limit, above all of these: compound 1.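

In this assay, going by these compounds alone, 4-hydroxy-3,3-dimethylcyclohexyl on this nitrogen gives a 2.1-fold lower number from compound 3 to compound 4 (0.32 log units; beyond the scatter) and a 2.1-fold lower number from compound 2 to compound 4 (0.32 log units; beyond the scatter) as well, the first steps here beyond the scatter with a number at both ends. Earlier, compound 2 and compound 3 stood level. The step of an at least 4.1-fold lower number from compound 1 to compound 4 (0.61 log units; beyond the scatter) is only a floor, as the value of compound 1 is a limit: the limit of > 10000 nM in this assay, at which 1 of the 4 values shown sits.

The compounds shown do not separate the hydroxy group from the two methyl groups, and plain 4-hydroxycyclohexyl would be needed for that. From the compounds shown here alone, how an amine in place of the hydroxy group would read here also remains open.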